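Swapping the methylphenyl of compound 3 for an aminophenyl

The source may hold more compounds than are shown below. What is called first, only, known or untested is meant among the compounds shown, and "the series" means these compounds.

Compound 3 `Cc1ccc(C(=O)N/N=C/C2=C(Cl)c3ccccc3CCC2)cc1` in a functional assay (MiaPaCa cells, Homo sapiens) for inhibition, read by sulforhodamine B assay, with a stated time of 48 h (on this read-out lower numbers stand for stronger inhibition of growth and higher numbers for weaker inhibition of growth), gives 10000 nM, the highest of the three numbers measured. Compound 1 `Cc1cc2c(cc1C)C(Cl)=C(C(=O)N/N=C\C1=C(Cl)c3ccccc3CCC1)CCC2` gives 6000 nM, and its gap to compound 3 is within the scatter. Among the measured compounds shown here, compound 2 `O=C(N/N=C/C1=C(Cl)c2ccccc2CCC1)c1ccccc1` gives 1000 nM, the one value that stands apart, because a 10-fold higher number from compound 2 to compound 3 (1.00 log units; beyond the scatter) lies beyond the scatter.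

Compound 4 `Nc1ccccc1C(=O)N/N=C/C1=C(Cl)c2ccccc2CCC1` differs from compound 3 by 2-aminophenyl in place of 4-methylphenyl on a carbonyl carbon. For the measured compounds named here, the only measured step at this part of the molecule is a 10-fold higher number from compound 2 to compound 3 (1.00 log units; beyond the scatter), which shows that a single substituent on this phenyl moved the number well beyond the scatter, with the unsubstituted compound 2 giving the lower value. Going by the values given here, no measured compound carries an amino group on this ring, so the direction of the change is not fixed by the data; the number for compound 4 is expected to fall between those of compound 2 and compound 3 rather than beyond either. Compound 4 is therefore estimated at 3000 nM, with a range from 600 nM to 15000 nM. This estimate means a step of a 3.3-fold lower number from compound 3 to compound 4 (0.52 log units; beyond the scatter) from the value of compound 3, expected to be modest.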

Compound 4, concentration for 50% growth inhibition: 65100 nM
Estimate against measurement, compound 4: 22-fold (1.34 log units) below; measured number outside the range, above it.
By their numbers in this assay, from the lowest: compound 2; then compounds 1 and 3 (each within the scatter of the next); then compound 4.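

In this assay, the 2-aminophenyl on the carbonyl carbon gives a 6.5-fold higher number from compound 3 to compound 4 (0.81 log units; beyond the scatter), so the change from the 4-methylphenyl does not land between the earlier values but moves past both. Read against the unsubstituted phenyl, the amino group gives a 65-fold higher number from compound 2 to compound 4 (1.81 log units; beyond the scatter), which means that both substituents measured on this ring, methyl and amino, raise the number, and neither gives a lower number than compound 2. Nothing shown here explains this rise.

The step from compound 3 to compound 4 changes both the group and its place on the ring, so the two effects cannot be separated. On these data alone, how a 4-aminophenyl or a 2-methylphenyl would compare stays open, as does whether any group on this ring, such as a methoxy or a fluorine, could give a lower number than compound 2.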